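The source may hold more compounds than are shown below. What is called first, only, known or untested is meant among the compounds shown, and "the series" means these compounds.

Of the compounds shown here, two have been measured in an assay on isolated protein for binding affinity to adenosine receptor A1 (Bos taurus); on this read-out higher numbers stand for weaker inhibition and lower numbers for stronger inhibition. Compound 1 `CCCCNc1nc(-c2ccccc2)nc2c1nnn2Cc1ccccc1` gives 11000000 nM, and compound 2 `CNc1nc(-c2ccccc2)nc2c1nnn2Cc1ccccc1F` gives 25000000 nM, the higher of the two numbers, a gap beyond the usual scatter. Compound 3 `CCCCNc1nc(-c2ccccc2)nc2c1nnn2Cc1ccccc1F` differs from compound 2 by one change: propyl in place of hydrogen on a saturated chain carbon bound to a nitrogen on an aromatic ring. Among the measured compounds shown here, since compound 1, which also carries a butylamino group, gave 11000000 nM, a modest move toward stronger binding seems reasonable, though no direct step is available. The step expected in this assay is a 2.5-fold lower number from compound 2 to compound 3 (0.40 log units; beyond the scatter). Compound 3 is therefore estimated at 10000000 nM, most likely between 3000000 nM and 40000000 nM.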

Compound 3, inhibition constant: 4300000 nM
For compound 3 the middle estimate is 2.3-fold (0.37 log units) above the measured one, within the range that was stated.
By their numbers in this assay, from the lowest: compound 3; then compound 1; then compound 2.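

In this assay, going from methylamino to butylamino with the fluoro group kept gives a 5.8-fold lower number from compound 2 to compound 3 (0.76 log units; beyond the scatter) and so moves toward stronger binding. Fluoro in place of hydrogen on an aromatic carbon, with butylamino kept, gives a 2.6-fold lower number from compound 1 to compound 3 (0.41 log units; beyond the scatter) and moves the same way, so both places affect the number. Nothing here gives a reason for either step. From the compounds shown here alone, whether a longer chain such as hexyl, or a ring such as cyclohexyl, would go further stays open. So does whether the fluoro step keeps its size alongside methylamino.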